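The source may hold more compounds than are shown below. What is called first, only, known or untested is meant among the compounds shown, and "the series" means these compounds.

In a functional assay on SK-BR-3 cells (Homo sapiens) for cytotoxicity, read by MTT assay, with a stated time of 72 h (a lower number here means a stronger inhibitor, a higher number a weaker inhibitor), measured so far:
- compound 1 `N[C@H]1CC[C@H](Nc2c(C(=O)NCc3ccc(F)cc3)nc(Br)c3cccnc23)CC1`: 2000 nM
- compound 2 `N[C@H]1CC[C@H](Nc2c(C(=O)NC3CCCCC3)nc(Br)c3cccnc23)CC1`: 4200 nM

Among the measured compounds shown here, of these two, compound 2 has the higher number, and compound 1 is its only measured neighbour. The next change leads to compound 3 `N[C@H]1CC[C@H](Nc2c(C(=O)Nc3ccccc3)nc(Br)c3cccnc23)CC1`, with phenyl in place of cyclohexyl on an amide-type nitrogen.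

For the measured compounds named here, one measured step bears on this, at the same nitrogen: a 2.1-fold higher number from compound 1 to compound 2 (0.32 log units; beyond the scatter). It is modest, and it is a single case, so no pattern can be claimed. Going by the values given here, no measured compound carries phenyl itself. Phenyl shares an aromatic ring with the 4-fluorobenzyl of compound 1, so a small move toward a lower number is expected in this assay, no larger than that measured step. The expected step is a 1.4-fold lower number from compound 2 to compound 3 (0.15 log units; within the scatter). For compound 3 the estimated value is 3000 nM, with an estimated range of 1300 nM to 7000 nM.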

Compound 3, half-maximal inhibitory concentration: 2000 nM
Beside the measured number, compound 3's estimate is 1.5-fold (0.18 log units) above it; low and high end bracket the measured number.
By their numbers in this assay, from the lowest: compounds 1 and 3 (each within the scatter of the next); then compound 2.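

In this assay, replacing cyclohexyl with phenyl on the amide-type nitrogen gives a 2.1-fold lower number from compound 2 to compound 3 (0.32 log units; beyond the scatter), so at this position a six-membered aromatic ring of carbon only and its non-aromatic counterpart, each with 6 heavy atoms, are told apart. Among the compounds shown here, replacing 4-fluorobenzyl with phenyl shows no change at the digits printed from compound 1 to compound 3 (within the scatter) and leaves the two aromatic groups together, with compound 2, the only one carrying a non-aromatic ring here, apart from both; this holds for these three compounds only. No measured evidence explains the difference between the rings.

Compound 1 differs from compound 3 in both its fluorine and its extra carbon link, and these two features remain unseparated. Also open, as far as these compounds go, is how unsubstituted benzyl, a longer phenethyl chain or an aminoalkyl chain on the same nitrogen would read in this assay.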